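Solubility notes: methoxy in place of cyclopropyl on the core

A few compounds are considered here, and "the series" means these few. Any claim that something is new, unique, unknown or untested is made for them only; others in the source may bear on it.

Compound 1 `CC(C)CS(=O)(=O)Nc1ccc(F)c(C(=O)Nc2cnc3[nH]nc(C4CC4)c3c2)c1Cl`: in a physicochemical assay for solubility, at pH 7.4 (on this read-out higher numbers stand for higher solubility and lower numbers for lower solubility), compound 1 reports only a limit, < 1 ug/mL.
Compound 2 `O=C(Nc1cnc2[nH]nc(C3CC3)c2c1)c1c(F)ccc(NS(=O)(=O)CCCF)c1Cl`: compound 2 gives 265 ug/mL.
Compound 3 `CCCS(=O)(=O)Nc1ccc(F)c(C(=O)Nc2cnc3[nH]nc(C4CC4)c3c2)c1Cl`: compound 3 gives 127 ug/mL.

Compound 3 stands lowest of the two numbers shown; compound 2 is its nearest neighbour, and the step of a 2.1-fold lower number from compound 2 to compound 3 (0.32 log units; beyond the scatter) is modest. Compound 1 sits at a limit (the limit of < 1 ug/mL in this assay, at which 1 of the 3 values shown sits), so the steps of an at least 260-fold higher number from compound 1 to compound 2 (2.42 log units; beyond the scatter) and an at least 120-fold higher number from compound 1 to compound 3 (2.10 log units; beyond the scatter) are bounds rather than exact sizes, both large and both rising from compound 1.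

Compound 4 `CCCS(=O)(=O)Nc1ccc(F)c(C(=O)Nc2cnc3[nH]nc(OC)c3c2)c1Cl` differs from compound 3 on the shared core: methoxy in place of cyclopropyl on an aromatic carbon. Within the data shown here, none of the measured steps bears on this position; all three concern the saturated chain bound to the sulfonyl sulfur, where changes ranged from modest to large. The core change has therefore no precedent within the shown compounds, and no step beyond the scatter is expected in either direction.

Compound 4 is expected to give 150 ug/mL, estimated between 50 ug/mL and 450 ug/mL. The implied step a 1.2-fold higher number from compound 3 to compound 4 (0.07 log units; within the scatter) is expected to fall within the usual scatter.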

Compound 4, solubility: 2 ug/mL
The estimate for compound 4 lay 75-fold (1.88 log units) above the measured number; measured number below the stated range.
By their numbers in this assay, from the lowest: compound 4; then compound 3; then compound 2. At a limit, below all of these: compound 1.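

The swap of cyclopropyl for methoxy on this aromatic carbon of the five-membered ring gives, in this assay, a 64-fold lower number from compound 3 to compound 4 (1.80 log units; beyond the scatter), so the shared core position is a strong handle on this read-out and not a neutral one. Earlier, large steps had appeared only at the saturated chain on the sulfonyl sulfur, as in an at least 120-fold higher number from compound 1 to compound 3 (2.10 log units; beyond the scatter); compound 4 keeps the chain of compound 3 and still drops, so that chain alone does not secure a high number across the series. Any further fall at this position may no longer be readable as a number, since compound 1 already reports only a limit: the limit of < 1 ug/mL in this assay, at which 1 of the 4 values shown sits.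

The compounds shown do not separate an effect of methoxy itself from the loss of the cyclopropyl ring, and they give no cause for the step. Ethoxy, cyclobutyl or a dimethylamino group at this position would help to separate the two, as would methoxy paired with the chain of compound 2, which would test whether the chain and core changes act independently.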